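The compounds below may be only part of what the source reports. "The series", "measured", "known", "first", "only" and "open" are said of these compounds alone.

Compound 1, `CC1(C)Oc2ccc(C#N)cc2[C@@H](/N=C(\NC#N)Oc2ccccc2)[C@@H]1O`: in a functional assay (aorta) with Rattus norvegicus as the target (a higher number here means a weaker inhibitor, a lower number a stronger inhibitor), compound 1 gives > 100000 nM, which is a limit of the assay rather than a number.
Compound 2, `CC1(C)Oc2ccc(C#N)cc2[C@@H](/N=C(\NC#N)Sc2ccccc2)[C@@H]1O`: in this assay compound 2 gives 4900 nM.
Compound 3, `CC(=O)c1ccc(N/C(=N/[C@@H]2c3cc(C#N)ccc3OC(C)(C)[C@H]2O)NC#N)cc1`: in this assay compound 3 gives 21000 nM.

Among the values shown, compound 3 has the highest number, so it is the weaker of the two compounds with a measured number; the step of a 4.3-fold higher number from compound 2 to compound 3 (0.63 log units; beyond the scatter) lies beyond the scatter. The other two measured steps, an at least 20-fold lower number from compound 1 to compound 2 (1.30 log units; beyond the scatter) and an at least 4.7-fold lower number from compound 1 to compound 3 (0.67 log units; beyond the scatter), likewise exchange the group on a carbon with a double bond to nitrogen, and one of them starts from a limit.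

Compound 4, `CC1(C)Oc2ccc(C#N)cc2[C@@H](/N=C(\NC#N)Nc2ccc3c(c2)CCC3)[C@@H]1O`, differs from compound 3 at another place: 2,3-dihydro-1H-inden-5-yl in place of 4-acetylphenyl on an amine nitrogen. Going by the values given here, none of the measured steps touches this position, so there is no measured step that bears on the change, and no direction can be read from the data. The change keeps the size of the group while removing its only hydrogen-bond acceptor. With no guide from the measured steps, the step of a 1.2-fold lower number from compound 3 to compound 4 (0.07 log units; within the scatter) is expected to stay within the scatter, with wide uncertainty. Compound 4 is therefore estimated at 18000 nM, with a range from 4000 nM to 80000 nM.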

Compound 4, half-maximal inhibitory concentration: 41300 nM
Beside the measured number, compound 4's estimate is 2.3-fold (0.36 log units) below it; measured number inside the range.
By their numbers in this assay, from the lowest: compound 2; then compounds 3 and 4 (each within the scatter of the next). At a limit, above all of these: compound 1.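

Replacing 4-acetylphenyl with 2,3-dihydro-1H-inden-5-yl on the amine nitrogen gives a 2.0-fold higher number from compound 3 to compound 4 (0.29 log units; within the scatter), so this position in this assay accepts a group with no hydrogen-bond acceptor in place of one that has one, without a change beyond the scatter. The second amine-linked group also stays apart from the phenylsulfanyl compound, as the first one did, with an 8.4-fold higher number from compound 2 to compound 4 (0.93 log units; beyond the scatter), so among the compounds shown, both amine-linked groups give weaker numbers than the sulfur-linked one. The change from phenoxy gives an at least 2.4-fold lower number from compound 1 to compound 4 (0.38 log units; beyond the scatter), and this step is only a bound, set by a limit of the assay for compound 1: the limit of > 100000 nM in this assay, at which 1 of the 4 values shown sits.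

Only two groups on the amine nitrogen are shown, so it stays open whether a benzyl group, a cyclohexyl ring or a plain butyl chain there would bring the number closer to that of compound 2. Also open, on these data alone, is whether 4-acetylphenyl or 2,3-dihydro-1H-inden-5-yl would give the same result attached through sulfur, as the phenyl ring is in compound 2.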